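Removing a Ring Methyl in Two Related Series

A few compounds are considered here, and "the series" means these few. Any claim that something is new, unique, unknown or untested is made for them only; others in the source may bear on it.

Compound 1 `CCC(C)(C)/N=c1\c(O)c(O)\c1=N/Cc1c(C)cc(C)cc1C` and compound 3 `CCC(C)(C)/N=c1\c(O)c(O)\c1=N/Cc1ccc(C)cc1C` share one core, while compound 2 `Cc1cc(Cl)cc(Cl)c1C/N=c1\c(O)c(O)\c1=N/C(C)C(C)(C)C` and compound 4 `CC(/N=c1\c(O)c(O)\c1=N/Cc1ccc(Cl)cc1Cl)C(C)(C)C` share another; the difference between the two cores is not broken down here. In a functional assay for inhibition, with Rattus norvegicus as the target (a higher number here means a weaker inhibitor, a lower number a stronger inhibitor), compound 1 gives 310 nM, and compound 3 gives 530 nM. The step of a 1.7-fold higher number from compound 1 to compound 3 (0.23 log units; within the scatter) comes from the change (hydrogen in place of methyl on an aromatic carbon). Compound 2 stands apart: in this assay compound 2 gives 9800 nM, the highest of the three numbers and beyond the scatter from both compound 1 and compound 3. Compound 4 has not yet been measured. It differs from compound 2 by hydrogen in place of methyl on an aromatic carbon, the same kind of change as that from compound 1 to compound 3, though here the aromatic carbon is meta to two chloro groups rather than meta to two methyl groups. Because a 1.7-fold higher number from compound 1 to compound 3 (0.23 log units; within the scatter) lies within the scatter, the step of a 1.3-fold higher number from compound 2 to compound 4 (0.12 log units; within the scatter) is expected to be small as well. Compound 4 is therefore estimated at 13000 nM in this assay, with a likely range from 4500 nM to 38000 nM.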

Compound 4, half-maximal inhibitory concentration: 340 nM
Beside the measured number, compound 4's estimate is 38-fold (1.58 log units) above it; measured number below the stated range.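

In this assay, the new step is a 29-fold lower number from compound 2 to compound 4 (1.46 log units; beyond the scatter), so the same swap of a ring methyl for hydrogen that made little difference on one core gives a much stronger inhibitor on the other. The change therefore does not carry over unchanged between these two cores: the same change on two cores in this assay, a 1.7-fold higher number (0.23 log units; within the scatter) from compound 1 to compound 3 and a 29-fold lower number (1.46 log units; beyond the scatter) from compound 2 to compound 4, 49-fold (1.69 log units) apart, beyond the scatter of two such steps

Within the data shown here, this means that a step read on one core was a poor guide to the same step on the other core here, although each core supplies only a single pair of compounds. It does not show which part of the difference between the cores lies behind the gap, nor how the change would behave on any third core.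

The compounds shown leave open whether a large step like this one would also appear with bromo or methoxy groups on the ring in place of the chloro groups. They also leave open whether a longer chain in place of the existing alkyl group would alter the size of the step.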